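The source may report more compounds than this note shows. Statements on the series, on what has been measured and on what is new or still open speak of the compounds shown alone.

- Compound 1 `CN(C)Cc1cc(C(=O)/C=C/c2ccc(Cl)cc2Cl)cc(CN(C)C)c1O`: 3090 nM
- Compound 2 `CN(C)Cc1cc(C(=O)/C=C/c2c(Cl)cccc2Cl)cc(CN(C)C)c1O`: 5880 nM
- Compound 3 `CN(C)Cc1cc(C(=O)/C=C/c2ccc(F)cc2)cc(CN(C)C)c1O`: 20000 nM

In a functional assay on cells (Tumor Cell line, Homo sapiens) for cytotoxicity (on this read-out higher numbers stand for weaker inhibition and lower numbers for stronger inhibition), compound 3 gives the highest number of the three, 20000 nM, making it the weakest inhibitor so far. Compound 4 `CN(C)Cc1cc(C(=O)/C=C/c2c(F)cccc2Cl)cc(CN(C)C)c1O` changes one place: 2-chloro-6-fluorophenyl stands in place of 4-fluorophenyl on a double-bonded chain carbon bound to a double-bonded chain carbon (2-chloro-6-fluorophenyl in place of 4-fluorophenyl on a double-bonded chain carbon bound to a double-bonded chain carbon). Among the measured compounds shown here, two measured steps bear on this change: a 3.4-fold higher number from compound 2 to compound 3 (0.53 log units; beyond the scatter) and a 6.5-fold higher number from compound 1 to compound 3 (0.81 log units; beyond the scatter). The dichlorophenyl pair itself shows a 1.9-fold higher number from compound 1 to compound 2 (0.28 log units; within the scatter). Compound 2 is the closest measured match, so a modest move to a lower number is expected in this assay. The expected change is a 2.5-fold lower number from compound 3 to compound 4 (0.40 log units; beyond the scatter). Compound 4 is estimated at 8000 nM, with an expected range of 3500 nM to 18000 nM.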

Compound 4, half-maximal inhibitory concentration: 9120 nM
Compound 4: the middle estimate sits 1.1-fold (0.06 log units) below what was measured, within the range that was stated.
By their numbers in this assay, from the lowest: compounds 1, 2 and 4 (each within the scatter of the next, the first and the last beyond it); then compound 3.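

Placing 2-chloro-6-fluorophenyl in place of 4-fluorophenyl on a double-bonded chain carbon bound to a double-bonded chain carbon gives a 2.2-fold lower number from compound 3 to compound 4 (0.34 log units; beyond the scatter) in this assay, while the same group still leaves a 3.0-fold higher number from compound 1 to compound 4 (0.47 log units; beyond the scatter) as the step from the 2,4-dichlorophenyl compound. Fluoro in place of chloro on an aromatic carbon, a change confined to one halogen for the first time, gives a 1.6-fold higher number from compound 2 to compound 4 (0.19 log units; within the scatter) and so stays within the scatter. Nothing measured here explains these differences.

The compounds shown leave open how this position would respond to a ring bearing an amine, a methoxy group or a carboxylic acid.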